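This account rests on a few compounds, and the source may have more. Where it says the series, first, only, none or still open, it means among the compounds named here.

In a functional assay on the whole organism for inhibition, with Felis catus as the target, with a stated time of 30 min (a higher number here means that more compound is needed for the effect, a lower number that less compound is needed), compound 1 `Cc1ccccc1OCCNCC(O)COc1ccccc1` gives 0.031 mg/kg, the lower of the two numbers available. Compound 2 `COc1ccccc1OCCNCC(O)COc1ccccc1` gives 0.063 mg/kg, while compound 3 `Cc1ccc(OCC(O)CNCCOc2ccccc2)cc1` gives "not active" (no number reported). Compound 4 `CCOCCNCC(O)COc1ccccc1` has not yet been measured. Its structure departs from that of compound 1 as follows: ethyl in place of 2-methylphenyl on an oxygen on a saturated carbon. Within the data shown here, only one measured step offers a size for comparison, a 2.0-fold higher number from compound 1 to compound 2 (0.31 log units; beyond the scatter). That step is modest, but it only exchanges methyl for methoxy on an aromatic carbon, whereas here the whole 2-methylphenyl group leaves. A much larger move towards a higher number is therefore expected in this assay, and a result without a number is also possible. The expected change is a 16-fold higher number from compound 1 to compound 4 (1.21 log units; beyond the scatter). For compound 4 the estimate is 0.5 mg/kg, with an expected range of 0.06 mg/kg to 4 mg/kg.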

Compound 4, dose for half-maximal effect: 0.047 mg/kg
Beside the measured number, compound 4's estimate is 11-fold (1.03 log units) above it; measured number below the stated range.
By their numbers in this assay, from the lowest: compounds 1, 4 and 2 (each within the scatter of the next, the first and the last beyond it).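

In this assay the number moves by a 1.5-fold higher number from compound 1 to compound 4 (0.18 log units; within the scatter) when ethyl replaces 2-methylphenyl on the oxygen. At this place, then, the whole aromatic ring can be exchanged for a small open chain without a change that stands out from the scatter, so this ring is not required for the effect in this pair. The data offer no measured explanation for this result.

As far as these compounds go, it remains open how a longer chain such as butyl would behave here. An amine or a carboxylic acid at the end of the ethyl chain is equally unresolved.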